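This account rests on a few compounds, and the source may have more. Where it says the series, first, only, none or still open, it means among the compounds named here.

Working notes on the series. Two compounds have numbers in a functional assay on A549 cells (Homo sapiens) for cytotoxicity, read by MTT assay, with a stated time of 48 h; a higher number here means a weaker inhibitor, a lower number a stronger inhibitor. Compound 1 `CN1CCC(NC(=O)c2ccc(Nc3ncc([N+](=O)[O-])c(NC4CCCC4)n3)cc2)CC1` gives 42300 nM in this assay. Compound 2 `CN1CCN(c2ccc(Nc3ncc(F)c(NC4CCCC4)n3)cc2)CC1` gives 37200 nM in this assay, the lowest of the two numbers, but compound 1 is its nearest neighbour and the gap between the two is within the scatter, so no order between them can be read.

Compound 3 `CCCNc1nc(Nc2ccc(N3CCN(C)CC3)cc2)ncc1F` has not been measured in this assay. It differs from compound 2 in one place: propyl in place of cyclopentyl on a nitrogen on an aromatic ring. Among the measured compounds shown here, no measured pair shows what this change does, so the expectation rests on compound 2 alone. The step from compound 2 to compound 3 in this assay is expected to be small, with no direction that can be separated from the scatter; the expected step is a 1.2-fold higher number from compound 2 to compound 3 (0.08 log units; within the scatter). Compound 3 is therefore expected to give about 45000 nM in this assay, with a range from 15000 nM to 140000 nM.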

Compound 3, half-maximal inhibitory concentration: 5100 nM
Estimate against measurement, compound 3: 8.8-fold (0.95 log units) above, outside the stated range (below it).
By their numbers in this assay, from the lowest: compound 3; then compounds 2 and 1 (each within the scatter of the next).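

Among the compounds shown here, the change from cyclopentylamino to propylamino gives the first one-place comparison, and in this assay it gives a 7.3-fold lower number from compound 2 to compound 3 (0.86 log units; beyond the scatter) with the rest of the structure held constant. The group on this nitrogen is therefore not silent in this assay, and here the open propyl chain reads lower than the five-membered carbon ring. This rests on a single pair, so it shows that the position responds but does not yet give a trend across groups on that nitrogen.

Going by these compounds, whether the ring itself or the number of carbons matters remains open, since a butyl chain, an isopropyl group or a cyclobutyl ring on the same nitrogen would be needed to separate the two. On these data alone, whether propyl gives a similar step on the core of compound 1 is also open. Nothing measured on these compounds accounts for the step.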